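A few compounds are considered here, and "the series" means these few. Any claim that something is new, unique, unknown or untested is made for them only; others in the source may bear on it.

Working notes on the series. The shared core is carried by compound 1 `COc1cc(Cc2nc3c(N)ncnc3n2CCO)cc(OC)c1OC` and compound 2 `COc1cc(Cc2nc3c(N)ncnc3n2CCCCCO)cc(OC)c1OC`; they differ only in the chain on the aromatic nitrogen. In a functional assay on MCF7 cells (Homo sapiens) for cytotoxicity (a higher number here means that more compound is needed for the effect, a lower number that less compound is needed), compound 1 gives 222000000 nM, while compound 2 gives 84900000 nM. Within the data shown here, the single measured step, a 2.6-fold lower number from compound 1 to compound 2 (0.42 log units; beyond the scatter), is the whole of the present picture, and compound 2 stands at the lower of the two numbers, with compound 1 as its only neighbour.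

Compound 3 `COc1cc(Cc2nc3c(N)ncnc3n2CC(C)CO)cc(OC)c1OC` is the next member to be measured. Relative to compound 2 the change is 1-(hydroxymethyl)ethyl in place of 4-hydroxybutyl on a saturated chain carbon bound to an aromatic nitrogen. The new chain is shorter than that of compound 2 and is branched, so it sits between the hydroxyethyl chain of compound 1 and the hydroxypentyl chain of compound 2 in length. Among the measured compounds shown here, only the step from compound 1 to compound 2 bears on this, and it was modest; a lengthening lowered the number, so a shortening is expected to raise it. As far as these compounds go, the change here is smaller than that step, and the branch is untested. A smaller rise is expected. For compound 3 in this assay the expected step is a 1.6-fold higher number from compound 2 to compound 3 (0.22 log units; within the scatter), giving an estimate of 140000000 nM with a range from 60000000 nM to 330000000 nM.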

Compound 3, half-maximal effective concentration: 49100000 nM
Compound 3: middle estimate off by 2.9-fold (0.46 log units), on the high side; measured number outside the range, below it.
By their numbers in this assay, from the lowest: compounds 3 and 2 (each within the scatter of the next); then compound 1.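

In this assay the step of a 1.7-fold lower number from compound 2 to compound 3 (0.24 log units; within the scatter) means that the branched 1-(hydroxymethyl)ethyl chain and the straight 4-hydroxybutyl chain cannot be told apart at this position, although the branched chain has fewer heavy atoms. Among these compounds, the step of a 4.5-fold lower number from compound 1 to compound 3 (0.66 log units; beyond the scatter) is beyond the scatter and is larger than the one step known earlier, a 2.6-fold lower number from compound 1 to compound 2 (0.42 log units; beyond the scatter), so a second chain now stands clear of compound 1, and this one is branched. Chain length alone therefore gives no steady order across the three compounds: compound 3 goes against the reading that shortening the chain of compound 2 moves the number back towards that of compound 1, though no cause for this can be given, as nothing on hand bears on the result.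

As far as these compounds go, it remains open whether the branch itself counts, which a straight 3-hydroxypropyl chain on the same nitrogen would help to settle. Also open, from the compounds shown here alone, are how a longer chain would read in this assay and whether an amine or a carboxylic acid could stand in place of the hydroxy group.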